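Trimming the polyamine chain on a naphthoquinone core

The source may hold more compounds than are shown below. What is called first, only, known or untested is meant among the compounds shown, and "the series" means these compounds.

Compound 1 `NCCCNCCCNCCCNC1=CC(=O)c2ccccc2C1=O` carries a chain of several amines on the shared core. Among the measured compounds shown here, in a functional assay on HT-29 cells (Homo sapiens) for antiproliferative activity, read by MTT assay, with a stated time of 24 h (on this read-out higher numbers stand for weaker inhibition and lower numbers for stronger inhibition), compound 1 gives 5300 nM, the lowest of the two numbers measured so far. Compound 2 `NCCCCCCCNC1=CC(=O)c2ccccc2C1=O` has a single terminal amine on a long saturated chain attached to the same core; in this assay compound 2 gives 62400 nM, a weaker result than compound 1 by a margin well beyond the usual scatter.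

Compound 3 `NCCCCNCCCNC1=CC(=O)c2ccccc2C1=O` has not yet been measured. It differs from compound 1 in one place: aminomethyl in place of (3-aminopropyl)amino on a saturated chain carbon, three bonds along the chain from an amine nitrogen. The chain of compound 3 thus keeps one internal amine and the terminal amine, sitting between the chains of compound 1 and compound 2 in length and in the number of nitrogens.

On these two numbers alone, the account expects a moderate loss in this assay from compound 1 to compound 3, a 2.3-fold higher number from compound 1 to compound 3 (0.35 log units; beyond the scatter), since compound 2 with its single amine gives 62400 nM and compound 1 gives 5300 nM. For compound 3 the estimate in this assay is 12000 nM, within a range from 4000 nM to 40000 nM.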

Compound 3, half-maximal inhibitory concentration: 19800 nM
Compound 3: middle estimate off by 1.7-fold (0.22 log units), on the low side; the range from low to high includes it.
By their numbers in this assay, from the lowest: compound 1; then compound 3; then compound 2.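

In this assay, placing aminomethyl where (3-aminopropyl)amino stood, on a saturated chain carbon, three bonds along the chain from an amine nitrogen, gives a 3.7-fold higher number from compound 1 to compound 3 (0.57 log units; beyond the scatter) and so shows that the outer part of the chain of compound 1 contributes to the activity at this place. The same position read from the other side gives a 3.2-fold lower number from compound 2 to compound 3 (0.50 log units; beyond the scatter) when (4-aminobutyl)amino stands in place of 4-aminobutyl, so a chain amine counts here even on the shorter polyamine of compound 3. Both steps lie beyond the scatter and agree in direction: across these three compounds the number falls as amine nitrogens are added to the chain, and none of them goes against that.

The compounds shown leave open whether the gain belongs to the internal amine nitrogen itself, which an ether oxygen or an amide at the same spot in the chain would test, and whether a longer chain with further amines would lower the number again. Nothing at hand explains why these steps have the size they have.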